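Swapping Naphthalen-2-yl for 3,4-Difluorophenyl in Compound 2

The source may report more compounds than this note shows. Statements on the series, on what has been measured and on what is new or still open speak of the compounds shown alone.

In a functional assay on A2780 cells (Homo sapiens) for antiproliferative activity, read by fluorescence, with a stated time of 72 h (a lower number here means a stronger inhibitor, a higher number a weaker inhibitor), compound 2 `CN1CCC(C(=O)N2Cc3c(NC(=O)c4ccc5ccccc5c4)n[nH]c3C2(C)C)CC1` gives 270 nM and compound 1 `CC1(C)c2[nH]nc(NC(=O)c3ccc(F)cc3)c2CN1C(=O)C1CCN(C2CC2)CC1` gives 380 nM, two values within the scatter of each other. Compound 3 `CC(=O)N1CCC(C(=O)N2Cc3c(NC(=O)c4ccc(F)cc4)n[nH]c3C2(C)C)CC1` reads > 10000 nM, which is a limit of the assay. Compound 4 `CN1CCC(C(=O)N2Cc3c(NC(=O)c4ccc(F)c(F)c4)n[nH]c3C2(C)C)CC1` has 3,4-difluorophenyl in place of naphthalen-2-yl on a carbonyl carbon. Among the measured compounds shown here, the one measured step, an at least 26-fold higher number from compound 1 to compound 3 (1.42 log units; beyond the scatter), is large, but it lies on the amine nitrogen, which compound 4 leaves as in compound 2, so it bears on this change only weakly. Compound 1, which also differs at that nitrogen, carries a fluorophenyl group on the carbonyl and gives 380 nM. A small change is therefore expected, a 1.3-fold higher number from compound 2 to compound 4 (0.11 log units; within the scatter), with no step beyond the scatter. For compound 4 the estimated value is 350 nM, with an expected range of 120 nM to 1000 nM.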

Compound 4, half-maximal inhibitory concentration: 100 nM
Compound 4: the middle estimate sits 3.5-fold (0.54 log units) above what was measured; the measured number lies below the stated range.
By their numbers in this assay, from the lowest: compound 4; then compounds 2 and 1 (each within the scatter of the next). At a limit, above all of these: compound 3.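

With the amine nitrogen left as in compound 2, the group on the carbonyl carbon proves able to shift the result on its own: 3,4-difluorophenyl in place of naphthalen-2-yl gives a 2.7-fold lower number from compound 2 to compound 4 (0.43 log units; beyond the scatter) in this assay. Among the compounds shown here, the earlier compounds could not show this, since the only step among them lay at the amine nitrogen. Here, the smaller group with one aromatic ring gives the lower number.

Going by these compounds, how a phenyl ring carrying a methoxy group or a nitrile in place of the fluorines would read stays open. Nothing measured here explains the drop.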